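Cytotoxicity on rat myoblasts: a thiazole in place of chlorophenyl

The source may report more compounds than this note shows. Statements on the series, on what has been measured and on what is new or still open speak of the compounds shown alone.

Within the data shown here, compound 1 `OC(c1ccc(Cl)cc1)(c1cccnc1)c1ccccc1Cl` gives 61300 nM in an ADME assay on L6 cells (Rattus norvegicus) for cytotoxicity, read by resazurin assay, with a stated time of 72 h (a lower number here means a stronger inhibitor, a higher number a weaker inhibitor), the only number so far. For compound 2 `[O-][n+]1cncc(C(O)(c2ccc(Cl)cc2)c2ccccc2Cl)c1` this assay returns only a limit, > 100000 nM. Among the measured compounds shown here, the one measured step, an at least 1.6-fold higher number from compound 1 to compound 2 (0.21 log units; that floor lies within the scatter), exchanges a different ring on the same saturated chain carbon; its floor sits within the scatter, and it rests on (the limit of > 100000 nM in this assay, at which 1 of the 2 values shown sits).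

Compound 3 `OC(c1ccc(Cl)cc1)(c1cccnc1)c1cnc(Cl)s1` carries 2-chloro-1,3-thiazol-5-yl in place of 2-chlorophenyl on a saturated chain carbon bound to two aromatic carbons and an oxygen on a saturated carbon. For the measured compounds named here, no measured step exchanges the 2-chlorophenyl, so the step from compound 1 to compound 2 is the only guide, and it says no more than that the number did not fall. For compound 3 the expected step is therefore a 1.1-fold higher number from compound 1 to compound 3 (0.06 log units; within the scatter), not beyond the scatter. Compound 3 is estimated at 70000 nM, with a range from 25000 nM to 160000 nM in this assay; a limit rather than a number is possible.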

Compound 3, half-maximal inhibitory concentration: > 100000 nM
Compound 3: no number, only a limit (the forecaster's own chance of this, stated with the estimate: 30%); at least 1.4-fold (0.15 log units) between middle value and limit.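

In this assay the 2-chlorophenyl place now has a measured change of its own, with 2-chloro-1,3-thiazol-5-yl entering on the saturated chain carbon: an at least 1.6-fold higher number from compound 1 to compound 3 (0.21 log units; that floor lies within the scatter). Going by these compounds, the result for compound 3 is a limit and not a number, the true size of this step stays unknown, and its floor alone does not separate it from the scatter. Exchanging this second ring, like the ring exchange in compound 2, gives no lower number, and the series now gathers at one limit: the limit of > 100000 nM in this assay, at which 2 of the 3 values shown sit.

On these data alone, whether any group at this place can bring the number down remains open, as no value shown lies below that of compound 1. As far as these compounds go, the part played by the chlorine on the thiazole is also open, including how an amine or a methyl group there would read.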